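The source may report more compounds than this note shows. Statements on the series, on what has been measured and on what is new or still open speak of the compounds shown alone.

Measured compounds:
- Compound 1, `COC(=O)C1=C(N)Oc2c(OC)cc(Br)cc2C1CC(=O)c1ccc(Cl)cc1`, gives 33.8% in a functional assay on MCF7 cells (Homo sapiens) for antiproliferative activity, read by sulforhodamine B assay, with a stated time of 72 h, tested at 30 uM; a lower number here means a stronger effect, a higher number a weaker effect of the compound at the concentration tested.
- Compound 2, `COC(=O)C1=C(N)Oc2ccc(Br)cc2C1CC(=O)c1ccc(Cl)cc1`, gives 32.4%.
- Compound 3, `COc1cccc(C(=O)CC2C(C#N)=C(N)Oc3c(OC)cc(Br)cc32)c1`, gives 33.9%.

All three numbers lie within the usual scatter of one another, so none of these compounds can be called the more or less active. The difference between the core of compound 1 and the core of compound 3 is not broken down here. One change has been measured: hydrogen in place of methoxy on an aromatic carbon, which gave a number 1.4 percentage points lower from compound 1 to compound 2 (within the scatter). Compound 4, `COc1cccc(C(=O)CC2C(C#N)=C(N)Oc3ccc(Br)cc32)c1`, is not yet measured; it arises from compound 3 by the same change, (hydrogen in place of methoxy on an aromatic carbon). Because the earlier step of a number 1.4 percentage points lower from compound 1 to compound 2 (within the scatter) stayed within the scatter, the step from compound 3 to compound 4 in this assay is expected to be a number 1.4 percentage points lower from compound 3 to compound 4 (within the scatter), likewise small. Compound 4 is therefore estimated at 32.5%, with a likely range from 22% to 43%.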

Compound 4, a percentage reported as activity, at one concentration (the size of the read-out at that concentration, not a potency): 34.4%
Compound 4: middle estimate off by 1.9 percentage points, on the low side, and the stated range covers the measured number.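

In this assay, hydrogen in place of methoxy on an aromatic carbon gave a number 0.5 percentage points higher from compound 3 to compound 4 (within the scatter). Set beside the earlier step, the change carries from one core to the other with no difference that can be told from the scatter: the same change on two cores in this assay, a number 1.4 percentage points lower (within the scatter) from compound 1 to compound 2 and a number 0.5 percentage points higher (within the scatter) from compound 3 to compound 4, 1.9 percentage points apart, within the scatter of two such steps This shows only that the change has a small effect on these two cores at the single concentration tested; it does not establish a direction for the step or the same outcome on any other core.

The compounds shown carry only methoxy or hydrogen at this place, so an amine, a carboxylic acid or a longer chain there remains open. All four also keep the bromo group, leaving open what a fluoro or iodo group in its place would give.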